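This account rests on a few compounds, and the source may have more. Where it says the series, first, only, none or still open, it means among the compounds named here.

Working notes on the series. In a functional assay on CCRF-CEM cells (Homo sapiens) for cytotoxicity, read by MTT assay, with a stated time of 72 h (on this read-out lower numbers stand for higher toxicity in this test and higher numbers for lower toxicity in this test), compound 1 `CCCCCCOC(=O)Nc1ccc([Se]C#N)cc1` gives 72700 nM. Among the compounds with values here, the only other measured compound, compound 2 `O=C(Nc1ccc([Se][Se]c2ccc(NC(=O)Oc3ccc(F)cc3)cc2)cc1)Oc1ccc(F)cc1`, gives 68800 nM in this assay, and the two numbers lie within the scatter of each other, so compound 1 cannot be placed apart from compound 2. Compound 3 `N#C[Se]c1ccc(NC(=O)Oc2ccccc2)cc1` differs from compound 1 by phenyl in place of hexyl on an oxygen next to a carbonyl group. Within the data shown here, no measured pair shows this change, so the step is expected to stay within the scatter, with no clear direction. For compound 3 the estimate in this assay is 65000 nM, in the range 20000 nM to 200000 nM, which means an expected step of a 1.1-fold lower number from compound 1 to compound 3 (0.05 log units; within the scatter).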

Compound 3, concentration lethal to 50% of the cells: 73200 nM
Estimate against measurement, compound 3: 1.1-fold (0.05 log units) below; the measured number falls inside the stated range.
By their numbers in this assay, from the lowest: compounds 2, 1 and 3 (each within the scatter of the next).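

In this assay, within the data shown here, phenyl in place of hexyl on an oxygen next to a carbonyl group gives a 1.0-fold higher number from compound 1 to compound 3 (0.00 log units; within the scatter) in the first measured pair for this change. At this position, the read-out therefore does not separate the aromatic ring from the open chain. No evidence on the reason for this result is available.

As far as these compounds go, whether a different kind of group on this oxygen, such as a longer chain or a chain carrying an amine or a carboxylic acid, would give a step beyond the scatter remains open.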